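A few compounds are considered here, and "the series" means these few. Any claim that something is new, unique, unknown or untested is made for them only; others in the source may bear on it.

Working notes on the series, read in a functional assay on HepG2 cells (Homo sapiens) for inhibition, read by MTT assay, with a stated time of 48 h; on this read-out higher numbers stand for weaker inhibition of growth and lower numbers for stronger inhibition of growth. For the measured compounds named here, compound 1 (`Cn1cc(C2CC(c3ccccc3)=NN2C(=O)c2ccc(Cl)nc2)c2ccccc21`) gives 7910 nM, the higher of the two true numbers so far. Compound 2 (`COc1ccc(C(=O)N2N=C(c3ccccc3)CC2c2cn(C)c3ccccc23)cn1`) gives 3130 nM. Compound 3 (`Cn1cc(C2CC(c3ccccc3)=NN2C(=O)c2cccnc2Cl)c2ccccc21`) gives > 10000 nM, which is a limit of the assay and not a number.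

The next compound to read is compound 4 (`Cn1cc(C2CC(c3ccccc3)=NN2C(=O)c2ccncc2)c2ccccc21`), and its difference from compound 1 is pyridin-4-yl in place of 6-chloropyridin-3-yl on a carbonyl carbon. In words, pyridin-4-yl stands in place of 6-chloropyridin-3-yl on a carbonyl carbon, while the core of compound 1 stays the same.

Three measured steps change the same carbonyl substituent. Methoxy in place of chloro gives a 2.5-fold lower number from compound 1 to compound 2 (0.40 log units; beyond the scatter). The move to 2-chloropyridin-3-yl gives an at least 1.2-fold higher number from compound 1 to compound 3 (0.10 log units; that floor lies within the scatter), and the same group against the methoxy compound gives an at least 3.1-fold higher number from compound 2 to compound 3 (0.50 log units; beyond the scatter). Going by the values given here, none of these is the change at hand, since no measured pair simply loses the chloro group, and they point in both directions. No clear direction is therefore expected in this assay, and no step beyond the scatter is anticipated. The expected step is a 1.1-fold lower number from compound 1 to compound 4 (0.05 log units; within the scatter). A reading at the limit of > 10000 nM in this assay, at which 1 of the 3 values shown sits, remains possible. For compound 4 the estimated value is 7000 nM, with an expected range from 3000 nM to 15000 nM.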

Compound 4, concentration for 50% growth inhibition: 630 nM
The estimate for compound 4 lay 11-fold (1.05 log units) above the measured number, and the stated range ends above it.
By their numbers in this assay, from the lowest: compound 4; then compound 2; then compound 1. At a limit, above all of these: compound 3.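

In this assay, for the compounds shown here, the carbonyl substituent proves able to shift the number much further than the earlier steps showed, with pyridin-4-yl giving a 13-fold lower number from compound 1 to compound 4 (1.10 log units; beyond the scatter) and a 5.0-fold lower number from compound 2 to compound 4 (0.70 log units; beyond the scatter). Compound 4 is therefore the strongest of the four on this read-out, and compounds 1, 2 and 3, each with a chloro or methoxy group on its pyridine, all stand weaker. Against compound 3 the step is an at least 15-fold lower number from compound 3 to compound 4 (1.20 log units; beyond the scatter), and this size is only a floor, since compound 3 stands at a limit of the assay and not at a number: the limit of > 10000 nM in this assay, at which 1 of the 4 values shown sits.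

Still open, going by these compounds, is how much of the gain comes from losing the chloro group and how much from pyridin-4-yl replacing a pyridin-3-yl attachment, a question that a plain pyridin-3-yl on the same carbonyl carbon would address. Also open, on these data alone, is whether pyridin-4-yl tolerates any added group, such as an amine or a carboxylic acid, and whether the gain carries over to a read-out other than this assay.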